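This account rests on a few compounds, and the source may have more. Where it says the series, first, only, none or still open, it means among the compounds named here.

Compound 1 `O=C1O[C@@H](CN2CCCCC2)CN1c1ccc(-n2cc(-c3ccccn3)cn2)c(F)c1` and compound 2 `O=C1CNC(=O)N1C[C@H]1CN(c2ccc(-n3cc(-c4ccccn4)cn3)c(F)c2)C(=O)O1` share one core and differ only by 2,5-dioxoimidazolidin-1-yl in place of piperidin-1-yl on a saturated chain carbon bound to a saturated ring carbon. In an ADME assay on HEK293-A cells (Homo sapiens) for cytotoxicity, read by MTT assay, with a stated time of 48 h (a higher number here means a weaker inhibitor, a lower number a stronger inhibitor), compound 1 gives > 400 ug/mL, a limit of the assay. In this assay compound 2 gives > 400 ug/mL, likewise a limit. The step that the two limits leave unreadable from compound 1 to compound 2 is therefore unreadable, both values sitting at the limit of > 400 ug/mL in this assay, at which 2 of the 2 values shown sit. Compound 3 `CC(=O)OC[C@H]1CN(c2ccc(-n3cc(-c4ccccn4)cn3)c(F)c2)C(=O)O1` introduces (acetoxy in place of 2,5-dioxoimidazolidin-1-yl on a saturated chain carbon bound to a saturated ring carbon). No readable step bears on this change, so the step of a number no higher from compound 2 to compound 3 (the limit leaves the size open) is expected to stay small. Compound 3 is thus expected to give 400 ug/mL, between 200 ug/mL and 800 ug/mL.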

Compound 3, half-maximal inhibitory concentration: > 400 ug/mL
Compound 3 was reported as a limit; the forecaster's own chance of this, stated with the estimate: 80%; the middle value sits exactly at the limit.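

In this assay compound 3 gives > 400 ug/mL, a limit of the assay. For the compounds shown here, no step among compound 1, compound 2 and compound 3 can be read: the limit of > 400 ug/mL in this assay, at which 3 of the 3 values shown sit. The compounds shown leave open whether piperidin-1-yl, 2,5-dioxoimidazolidin-1-yl and acetoxy differ at all in this assay.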